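A Second Fluoro on the Carbamoyl Phenyl Ring

A few compounds are considered here, and "the series" means these few. Any claim that something is new, unique, unknown or untested is made for them only; others in the source may bear on it.

Three compounds have numbers in a functional assay on PANC-1 cells (Homo sapiens) for inhibition, read by MTT assay, with a stated time of 24 h, tested at 10 uM; a higher number here means more inhibition at the concentration tested (going by the name of the read-out), a lower number less inhibition:
compound 1, `CC(C)=CCC/C(C)=C/COc1cc(=O)n(CCCO)c2c1CC(CC=C(C)C)C(C)(C)C2`, gives 10.6%;
compound 2, `CC(C)=CCC1Cc2c(OCCCNC(=O)c3cccs3)cc(=O)n(CCCO)c2CC1(C)C`, gives 33.6%;
compound 3, `CC(C)=CCC1Cc2c(OC(=O)Nc3ccc(F)cc3)cc(=O)n(CCCO)c2CC1(C)C`, gives 71.2%.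

Compound 3 stands highest of the three in this assay; its nearest neighbour is compound 2, and the step of a number 37.6 percentage points higher from compound 2 to compound 3 (beyond the scatter) lies beyond the scatter, as does the step of a number 60.6 percentage points higher from compound 1 to compound 3 (beyond the scatter). The smaller step of a number 23 percentage points higher from compound 1 to compound 2 (beyond the scatter) is also beyond the scatter.

Compound 4, `CC(C)=CCC1Cc2c(OC(=O)Nc3ccc(F)c(F)c3)cc(=O)n(CCCO)c2CC1(C)C`, differs from compound 3 in one place: fluoro in place of hydrogen on an aromatic carbon. Every measured step here swaps one whole group on the oxygen of the shared core for another of a different kind, so none of them bears directly on adding a single fluoro to the phenyl ring that compound 3 already carries. Among the measured compounds shown here, with no step of this kind measured, the expectation in this assay is for compound 4 to stay close to compound 3, so a number 1.2 percentage points lower from compound 3 to compound 4 (within the scatter) is estimated to fall within the scatter. Compound 4 is therefore expected to give about 70%, between 52% and 86%.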

Compound 4, a percentage reported as inhibition, at one concentration (the size of the read-out at that concentration, not a potency): 76.7%
Estimate against measurement, compound 4: 6.7 percentage points below; measured number inside the range.
By their numbers in this assay, from the lowest: compound 1; then compound 2; then compounds 3 and 4 (each within the scatter of the next).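

Going from 4-fluorophenyl to 3,4-difluorophenyl gives a number 5.5 percentage points higher from compound 3 to compound 4 (within the scatter) in this assay and is the first change shown on the phenyl ring itself, so a fluoro placed ortho to a fluoro group and meta to a large group leaves the two compounds level here. The (3,4-difluorophenyl)carbamoyl group keeps the large lead seen for the (4-fluorophenyl)carbamoyl group over the other groups on that oxygen, with a number 43.1 percentage points higher from compound 2 to compound 4 (beyond the scatter) and a number 66.1 percentage points higher from compound 1 to compound 4 (beyond the scatter) as the steps that show it. Nothing available explains why the added fluoro leaves the read-out level.

From the compounds shown here alone, whether a chlorine, a methoxy group or an amine at this same place would also leave the number level stays open. So does the effect of a phenyl ring with no fluoro at all on the carbamoyl group.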